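The source may report more compounds than this note shows. Statements on the series, on what has been measured and on what is new or still open speak of the compounds shown alone.

Working notes on the series.

Compound 2 `COc1cc2cc(Oc3ccc(NC(=O)Nc4ccc(Cl)c(C(F)(F)F)c4)cc3)c(C)nc2cc1OC` gives 1210 nM in a functional assay on T47D cells (Homo sapiens) for inhibition, read by sulforhodamine B assay, with a stated time of 48 h; on this read-out higher numbers stand for weaker inhibition of growth and lower numbers for stronger inhibition of growth. Within the data shown here, only one other compound has been measured in this assay: compound 1 `COc1cc2cc(Oc3ccc(NC(=O)Nc4cccc(C(F)(F)F)c4)cc3)c(C)nc2cc1OC`, which gives 1610 nM. The step between them, a 1.3-fold lower number from compound 1 to compound 2 (0.12 log units; within the scatter), lies within the scatter, so compound 2 and compound 1 cannot be separated on these numbers; compound 2 simply stands as one of two measured points, with nothing shown to rank it.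

Compound 3 `COc1cc2cc(Oc3ccc(NC(=O)Nc4ccc(Cl)c(Cl)c4)cc3)c(C)nc2cc1OC` continues from compound 2 by chloro in place of trifluoromethyl on an aromatic carbon, at an aromatic carbon of a six-membered aromatic ring of carbon only, ortho to a chloro group and meta to a large group, so that the urea carries 3,4-dichlorophenyl in place of 4-chloro-3-(trifluoromethyl)phenyl. Among the measured compounds shown here, no measured step exchanges trifluoromethyl for chloro. For the measured compounds named here, the one known step, a 1.3-fold lower number from compound 1 to compound 2 (0.12 log units; within the scatter), concerns a different change and was itself within the scatter; it gives no direction for the present exchange. For compound 3 no step beyond the scatter is therefore expected in this assay, the estimated step being a 1.2-fold higher number from compound 2 to compound 3 (0.06 log units; within the scatter). Compound 3 is estimated at 1400 nM, with a range from 500 nM to 4000 nM.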

Compound 3, concentration for 50% growth inhibition: 2700 nM
The estimate for compound 3 lay 1.9-fold (0.29 log units) below the measured number, within the range that was stated.
By their numbers in this assay, from the lowest: compounds 2, 1 and 3 (each within the scatter of the next, the first and the last beyond it).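

In this assay, among these compounds, chloro in place of trifluoromethyl on this aromatic carbon, ortho to a chloro group and meta to a large group, comes with a 2.2-fold higher number from compound 2 to compound 3 (0.35 log units; beyond the scatter); this is the first step beyond the scatter, and it shows that the number responds, modestly, to the group held at this position. The response is narrow, however: a 1.7-fold higher number from compound 1 to compound 3 (0.22 log units; within the scatter) stays within the scatter, so 3,4-dichlorophenyl and 3-(trifluoromethyl)phenyl on the amide-type nitrogen cannot be separated, and the exchange can be read only between 4-chloro-3-(trifluoromethyl)phenyl and 3,4-dichlorophenyl. No supporting evidence bears on this step, so its origin stays unassigned.

From the compounds shown here alone, whether a methoxy group, a nitrile or an amine on this carbon would stand with compound 2, with compound 3 or apart from both remains open. Among the compounds shown here, also open is whether the exchange of trifluoromethyl for chloro gives a step of this size when no chloro group lies ortho to it, since that single pair is the only reading of this change so far.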